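A methoxy group gives way to hydrogen

The compounds below may be only part of what the source reports. "The series", "measured", "known", "first", "only" and "open" are said of these compounds alone.

Compound 1 `FC(F)(F)c1cccc(NC(=S)Nc2ccc(I)cc2)c1` gives 9400 nM
Compound 2 `CCCC[C@H]1CC[C@H](c2ccc(NC(=S)Nc3cccc(C(F)(F)F)c3)cc2)CC1` gives 9500 nM
Compound 3 `COc1cccc(NC(=S)Nc2cccc(C(F)(F)F)c2)c1` gives 12000 nM

All three numbers come from an ADME assay on BHK cells (Mesocricetus auratus) for cytotoxicity, read by MTT assay, with a stated time of 96 h (a higher number here means that more compound is tolerated, a lower number that less compound is tolerated), and they lie close together. Compound 3 stands at 12000 nM within the scatter of both compound 1 and compound 2, so these numbers do not rank the three compounds.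

Compound 4 `FC(F)(F)c1cccc(NC(=S)Nc2ccccc2)c1` has yet to be measured in this assay and differs from compound 3 in one place. It carries hydrogen in place of methoxy on an aromatic carbon and the rest of the structure is shared.

Going by the values given here, no measured step removes a methoxy group, so the evidence is indirect. Among the compounds with values here, the only measured step is a 1.0-fold higher number from compound 1 to compound 2 (0.00 log units; within the scatter) and it concerns a different exchange of groups. Even that change of 4-butylcyclohexyl in place of iodo on an aromatic carbon left the number within the scatter. With so little to go on, no step beyond the scatter is expected in this assay and no firm direction can be given. The estimate therefore starts from compound 3 at 12000 nM and stays near it. The expected step is a 1.1-fold higher number from compound 3 to compound 4 (0.03 log units; within the scatter) and this remains only an estimate. Compound 4 is estimated at 13000 nM with 5500 nM to 32000 nM as the expected range.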

Compound 4, half-maximal cytotoxic concentration: 41000 nM
Estimate against measurement, compound 4: 3.2-fold (0.50 log units) below; the whole stated range lies below it.
By their numbers in this assay, from the lowest: compounds 1, 2 and 3 (each within the scatter of the next); then compound 4.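

The new compound shows that this position is not indifferent in this assay: with hydrogen in place of methoxy on the aromatic carbon, the result is a 3.4-fold higher number from compound 3 to compound 4 (0.53 log units; beyond the scatter) and more compound is tolerated. The same holds for the two other groups, with hydrogen in place of 4-butylcyclohexyl giving a 4.3-fold higher number from compound 2 to compound 4 (0.64 log units; beyond the scatter) and hydrogen in place of iodo giving a 4.4-fold higher number from compound 1 to compound 4 (0.64 log units; beyond the scatter), so all three substituted compounds stand apart from compound 4, although the numbers of compounds 1, 2 and 3 did not separate from one another. Nothing measured here accounts for this shift, so the data record only that it occurs.

From the compounds shown here alone, what remains open is whether any group on this aromatic carbon goes with the lower number, or whether a fluorine atom, a hydroxyl or an amine would stay closer to compound 4 than methoxy, iodo and 4-butylcyclohexyl do. All four compounds also share the trifluoromethyl group, so how the number would respond if that group were exchanged for a nitrile or a carboxylic acid cannot be read from them.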